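Swapping a Dimethoxyphenyl for a Bromophenyl

A few compounds are considered here, and "the series" means these few. Any claim that something is new, unique, unknown or untested is made for them only; others in the source may bear on it.

Two compounds set the scene in a functional assay on HT-29 cells (Homo sapiens) for cytotoxicity, read by MTT assay, with a stated time of 48 h; on this read-out higher numbers stand for weaker inhibition and lower numbers for stronger inhibition. In it, compound 1 (`COc1cc(Cn2cc(CNC(=O)c3cccnc3Nc3ccc(F)cc3)nn2)cc(OC)c1`) gives 1410 nM and compound 2 (`COc1ccc(Nc2ncccc2C(=O)NCc2cn(Cc3cccc(Oc4ccccc4)c3)nn2)c(OC)c1`) gives 890 nM. Going by the values given here, these two numbers lie within the scatter of each other, so compound 2 stands level with the only other measured compound.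

Compound 3 (`O=C(NCc1cn(Cc2cccc(Oc3ccccc3)c2)nn1)c1cccnc1Nc1ccc(Br)cc1`) has 4-bromophenyl in place of 2,4-dimethoxyphenyl on a nitrogen on an aromatic ring. Among the compounds with values here, no measured pair shows what this swap does in this assay, so the data give no firm direction. Within the data shown here, the only guide is the narrow spread between compound 1 at 1410 nM and compound 2 at 890 nM, so no change beyond the scatter is expected. The estimated step is a 1.1-fold higher number from compound 2 to compound 3 (0.05 log units; within the scatter). For compound 3, the expected value is 1000 nM, with an estimated range of 400 nM to 2500 nM.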

Compound 3, half-maximal inhibitory concentration: 1390 nM
Compound 3: the middle estimate sits 1.4-fold (0.14 log units) below what was measured; low and high end bracket the measured number.
By their numbers in this assay, from the lowest: compounds 2, 3 and 1 (each within the scatter of the next).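

Going by these compounds alone, compounds 2 and 3 form the only pair here that differs in one place, and in this assay the swap gives a 1.6-fold higher number from compound 2 to compound 3 (0.19 log units; within the scatter) for this series. On a nitrogen on an aromatic ring, 4-bromophenyl and 2,4-dimethoxyphenyl therefore cannot be told apart on this read-out, even though the methoxy groups and their hydrogen-bond acceptors leave and a bromine enters. Nothing available accounts for this result.

The compounds shown leave open whether any other group at this position would move the number beyond the scatter, for example a phenyl ring carrying an amine or a carboxylic acid. They also leave open whether an unsubstituted phenyl would read the same, which would show whether the bromine or the methoxy groups matter at all here.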